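A Trifluoromethyl for Fluoro on the Benzamide Ring

This account rests on a few compounds, and the source may have more. Where it says the series, first, only, none or still open, it means among the compounds named here.

Compound 1 `CCOc1ccccc1C(=O)Nc1nc(-c2ccccc2)nc2c1nnn2Cc1ccccc1`: 1850 nM
Compound 2 `Cc1ccc(C(=O)Nc2nc(-c3ccccc3)nc3c2nnn3Cc2ccccc2)cc1`: 709 nM
Compound 3 `O=C(Nc1nc(-c2ccccc2)nc2c1nnn2Cc1ccccc1)c1cccc(F)c1`: 22 nM

These three compounds share one core and differ only in the ring attached to the carbonyl carbon. In an assay (strain Wistar) for displacement of a labelled ligand from adenosine receptor A1 (Rattus norvegicus), read by scintillation counting (on this read-out lower numbers stand for stronger inhibition and higher numbers for weaker inhibition), compound 3 gives the lowest of the three numbers; the nearest stands as a 32-fold lower number from compound 2 to compound 3 (1.51 log units; beyond the scatter) and the furthest as an 84-fold lower number from compound 1 to compound 3 (1.92 log units; beyond the scatter). Compound 4 `O=C(Nc1nc(-c2ccccc2)nc2c1nnn2Cc1ccccc1)c1cccc(C(F)(F)F)c1` has not been measured; it carries trifluoromethyl in place of fluoro on an aromatic carbon. Among the measured compounds shown here, no measured step makes this exact change, but the two large steps just named show that the group on this ring can move the number a great deal, while a 2.6-fold lower number from compound 1 to compound 2 (0.42 log units; beyond the scatter) is only modest. A modest step, most likely towards a higher number, is therefore expected: a 1.8-fold higher number from compound 3 to compound 4 (0.26 log units; within the scatter). Compound 4 is estimated at 40 nM, with a range from 8 nM to 200 nM.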

Compound 4, inhibition constant: 163 nM
The estimate for compound 4 lay 4.1-fold (0.61 log units) below the measured number, within the range that was stated.
By their numbers in this assay, from the lowest: compound 3; then compound 4; then compound 2; then compound 1.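

Trifluoromethyl in place of fluoro on this ring carbon is not an interchangeable swap, with a 7.4-fold higher number from compound 3 to compound 4 (0.87 log units; beyond the scatter), so carrying fluorine is not enough to keep the number of compound 3. Even so, the 3-(trifluoromethyl)phenyl ring still compares well with the other two rings, with a 4.3-fold lower number from compound 2 to compound 4 (0.64 log units; beyond the scatter) and an 11-fold lower number from compound 1 to compound 4 (1.05 log units; beyond the scatter) as the steps to it. No measurement here accounts for the difference between fluoro and trifluoromethyl. Open, from the compounds shown here alone, is where a chloro group or an amine on this same carbon would fall relative to compound 3 and compound 4.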